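Para-methyl on the anilino ring of compound 2

This account rests on a few compounds, and the source may have more. Where it says the series, first, only, none or still open, it means among the compounds named here.

Compound 2, whose structure is `O=C(Nc1ccc(S(=O)(=O)Nc2ccccc2)cc1)c1ccc(Cl)cc1Cl`, gives 457 nM in a functional assay on HEK293 cells for agonist activity at probable G-protein coupled receptor 27 (Homo sapiens), read by a luciferase reporter and beta-arrestin recruitment, with a stated time of 10 min; on this read-out higher numbers stand for an effect only at larger amounts of compound and lower numbers for an effect already at smaller amounts. That is the lower of the two numbers in hand: compound 1, with structure `CN(c1ccccc1)S(=O)(=O)c1ccc(NC(=O)c2ccc(Cl)cc2Cl)cc1`, gives 2570 nM, and the step from compound 1 to compound 2, hydrogen in place of methyl on a sulfonamide nitrogen, is a 5.6-fold lower number from compound 1 to compound 2 (0.75 log units; beyond the scatter). Compound 3, with structure `Cc1ccc(NS(=O)(=O)c2ccc(NC(=O)c3ccc(Cl)cc3Cl)cc2)cc1`, has not yet been measured. It differs from compound 2 by methyl in place of hydrogen on an aromatic carbon, a methyl in place of hydrogen on an aromatic carbon, para to a large group, so that the anilino group becomes a (4-methylphenyl)amino group. Among the compounds with values here, no measured step concerns this position; the one step known touches the sulfonamide nitrogen, not the anilino ring, and its size offers no direct guide. For compound 3 the step from compound 2 is expected to be a 1.0-fold lower number from compound 2 to compound 3 (0.01 log units; within the scatter), within the scatter. The estimate for compound 3 is therefore 450 nM, with a range from 150 nM to 1400 nM.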

Compound 3, half-maximal effective concentration: > 100000 nM
Compound 3 was reported as a limit; the forecaster's own chance of this, stated with the estimate: 5%; middle value at least 220-fold (2.34 log units) from the limit.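

For compound 3 the read-out in this assay is a limit and not a number: the limit of > 100000 nM in this assay, at which 1 of the 3 values shown sits. Within the data shown here, it shows that the anilino ring, untouched by the earlier compounds, does not accept this change freely: a single methyl in place of hydrogen, para to a large group, gives an at least 210-fold higher number from compound 2 to compound 3 (2.34 log units; beyond the scatter). The methyl on the sulfonamide nitrogen had already raised the number, yet the methyl on the ring goes further, and the change from methyl(phenyl)amino to (4-methylphenyl)amino gives an at least 38-fold higher number from compound 1 to compound 3 (1.59 log units; beyond the scatter).

Whether this loss belongs to methyl alone remains open, as the compounds shown include no fluorine, chlorine or methoxy group at the same place. As far as these compounds go, it is also open whether an amine or a carboxylic acid there would behave like the hydrogen of compound 2 or like the methyl of compound 3.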